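This account rests on a few compounds, and the source may have more. Where it says the series, first, only, none or still open, it means among the compounds named here.

The series shares one core, carried by three compounds with numbers in hand. Compound 1 `Cc1ccc(-c2cs/c(=N/NC(=O)CSc3nnnn3-c3ccccc3)n2-c2ccccc2)cc1` gives 66.8% in a functional assay on C6 cells (Rattus norvegicus) for cytotoxicity, read by MTT assay, with a stated time of 24 h, tested at 6 ug/mL; on this read-out lower numbers stand for a stronger effect and higher numbers for a weaker effect at the one concentration tested. Compound 2 `Cn1nnnc1SCC(=O)N/N=c1/scc(-c2ccccc2)n1-c1ccccc1` gives 85.2% in this assay. Compound 3 `O=C(CSc1ncccn1)N/N=c1/scc(-c2ccc(Br)cc2)n1-c1ccccc1` gives 76.4% in this assay. On these three numbers compound 3 sits with the others inside the usual scatter of such measurements: compound 2 is its nearest neighbour and compound 1 its furthest, and neither gap reaches beyond that scatter, so no order among the three can be read from them.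

Compound 4 `O=C(CSc1ncccn1)N/N=c1/scc(-c2ccc(F)cc2)n1-c1ccccc1` is the compound still to be measured. It differs from compound 3 in one place (fluoro in place of bromo on an aromatic carbon), fluoro in place of bromo on an aromatic carbon. Among the compounds with values here, no pair of measured compounds shows this change, so its size is open. Nothing among the three numbers points one way, and the estimated step from compound 3 to compound 4 is a number 1.6 percentage points higher from compound 3 to compound 4 (within the scatter), not beyond the scatter in either direction. Compound 4 is therefore expected to give about 78% in this assay, within a range from 62% to 92%.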

Compound 4, a percentage reported as activity, at one concentration (the size of the read-out at that concentration, not a potency): 84%
Estimate against measurement, compound 4: 6 percentage points below, and the stated range covers the measured number.
By their numbers in this assay, from the lowest: compounds 1, 3, 4 and 2 (each within the scatter of the next, the first and the last beyond it).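

Exchanging 4-bromophenyl for 4-fluorophenyl gives the series its first reading of a single change: in this assay the step reads a number 7.6 percentage points higher from compound 3 to compound 4 (within the scatter) and so does not separate the two halogens. Within the data shown here, on this aromatic carbon, para to a large group, fluoro and bromo therefore cannot be told apart on this read-out, a point that the earlier compounds, none of which formed such a pair, could not address. Nothing measured here speaks to a cause for this step.

On these data alone, it remains open whether an amine or a carboxylic acid in place of the halogen would give a step beyond the scatter. Also open, as far as these compounds go, is whether the same exchange would read alike in compounds that carry a different side chain on the shared core.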